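This account rests on a few compounds, and the source may have more. Where it says the series, first, only, none or still open, it means among the compounds named here.

Measured in a functional assay on MCF7 cells (Homo sapiens) for inhibition, read by MTT assay, with stated times of 18 h and 4 h; on this read-out lower numbers stand for stronger inhibition and higher numbers for weaker inhibition:
Compound 1 `CCCCCCCCCCCCCCCCOP(=O)(O)OCCSC(=S)N1CCN(C)CC1`: > 100000 nM, a limit of the assay and not a number
Compound 2 `CCCCCCCCCCOP(=O)(O)OCCSC(=S)N1CCN(C)CC1`: 99600 nM
Compound 3 `CCCCCCCCOP(=O)(O)OCCSC(=S)N1CCN(C)CC1`: 46000 nM

Compound 1 gives no number, only a limit: the limit of > 100000 nM in this assay, at which 1 of the 3 values shown sits. The next compound, compound 4 `CCCCCCCCCCCCCCCCOP(=O)(O)OCCSC(=S)N1CCCCC1`, keeps the chain of compound 1 and carries piperidin-1-yl in place of 4-methylpiperazin-1-yl on a thiocarbonyl carbon.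

The three measured steps all change the chain, and none of them touches this group. The step of a 2.2-fold lower number from compound 2 to compound 3 (0.34 log units; beyond the scatter) is modest, the step of an at least 2.1-fold lower number from compound 1 to compound 3 (0.33 log units; beyond the scatter) is at least modest, and the step of a number no higher from compound 1 to compound 2 (the limit leaves the size open) cannot be sized. Across compounds 1, 2 and 3 the number does not rise as the chain shortens, and none of the three goes against this. These steps therefore bear on compound 4 only indirectly, since its chain stays as it is, and they give no measured size for the exchange itself.

No step beyond the scatter is expected in this assay, and another reading that stops at a limit is quite possible. The expected step is a number no higher from compound 1 to compound 4 (the limit leaves the size open). For compound 4 the estimate is 100000 nM, with an expected range from 40000 nM to 200000 nM.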

Compound 4, half-maximal inhibitory concentration: 29000 nM
Beside the measured number, compound 4's estimate is 3.4-fold (0.54 log units) above it, and the stated range ends above it.
By their numbers in this assay, from the lowest: compounds 4 and 3 (each within the scatter of the next); then compound 2. At a limit, above all of these: compound 1.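

In this assay, among these compounds, the group on the thiocarbonyl carbon proves to be a place where a change counts, something the earlier compounds could not show, as all their steps lay in the chain. With the chain of compound 1 kept, piperidin-1-yl in place of 4-methylpiperazin-1-yl gives an at least 3.4-fold lower number from compound 1 to compound 4 (0.53 log units; beyond the scatter), so this exchange alone is enough to move the read-out from a limit to a measured number, and a long chain does not by itself rule out a measured number here. The true size of this step stays open, because compound 1 has only a limit and not a number: the limit of > 100000 nM in this assay, at which 1 of the 4 values shown sits.

The compounds shown do not tell whether the same exchange would give a similar step on the shorter chains of compound 2 and compound 3, or which part of the exchange matters, the second ring nitrogen or its methyl. Going by these compounds, it also remains open how other groups on the thiocarbonyl carbon, such as morpholin-4-yl, piperazin-1-yl or an open-chain diethylamino group, would read in this assay.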